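Replacing the 5-bromopentyl group of compound 3

The source may hold more compounds than are shown below. What is called first, only, known or untested is meant among the compounds shown, and "the series" means these compounds.

In a functional assay on HL-60 cells (Homo sapiens) for cytotoxicity, read by MTT assay, with a stated time of 24 h (on this read-out higher numbers stand for weaker inhibition and lower numbers for stronger inhibition), compound 1 `BrCCCCOc1c(Br)cc(Br)cc1Oc1ccc(Br)cc1Br` gives 25.9 ug/mL, compound 2 `BrCCCCCCOc1c(Br)cc(Br)cc1Oc1ccc(Br)cc1Br` gives 37.8 ug/mL and compound 3 `BrCCCCCOc1c(Br)cc(Br)cc1Oc1ccc(Br)cc1Br` gives 25.7 ug/mL. Compound 3 thus stands within the scatter of both others. Compound 4 `CC(C)(C)C(=O)C(C#N)Oc1c(Br)cc(Br)cc1Oc1ccc(Br)cc1Br` carries cyano((tert-butyl)carbonyl)methyl in place of 5-bromopentyl on an oxygen on an aromatic ring. The measured steps bear on this only partly. The changes a 1.0-fold lower number from compound 1 to compound 3 (0.00 log units; within the scatter), a 1.5-fold lower number from compound 2 to compound 3 (0.17 log units; within the scatter) and a 1.5-fold higher number from compound 1 to compound 2 (0.16 log units; within the scatter) all stay within the scatter, but each only alters the bromoalkyl chain length. No clear shift in either direction is therefore expected, though with wide uncertainty. The estimated change is a 1.2-fold lower number from compound 3 to compound 4 (0.07 log units; within the scatter). Compound 4 is expected at 22 ug/mL, with an estimated range from 9 ug/mL to 55 ug/mL.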

Compound 4, half-maximal inhibitory concentration: 29.2 ug/mL
For compound 4 the middle estimate is 1.3-fold (0.12 log units) below the measured one, and the stated range covers the measured number.
By their numbers in this assay, from the lowest: compounds 3, 1, 4 and 2 (each within the scatter of the next).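

In this assay the swap to cyano((tert-butyl)carbonyl)methyl on an oxygen on an aromatic ring gives a 1.1-fold higher number from compound 3 to compound 4 (0.06 log units; within the scatter) and a 1.3-fold lower number from compound 2 to compound 4 (0.11 log units; within the scatter) and a 1.1-fold higher number from compound 1 to compound 4 (0.05 log units; within the scatter) and all three lie within the scatter. The earlier compounds shown here varied only the length of the bromoalkyl chain, whereas this change removes the chain and its bromine and brings in a carbonyl and a nitrile without moving the number beyond the scatter. On these data alone, whether an amine, a carboxylic acid or a plain methyl on this oxygen would do the same remains open. No supporting data on the cause of this flat result are available here.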